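The source may report more compounds than this note shows. Statements on the series, on what has been measured and on what is new or still open speak of the compounds shown alone.

Compound 2 `Cc1ccc2c(NCc3ccc(NC(=O)C4CCN(Cc5ccccc5)CC4)cc3)nc(N3CCNC(CCO)C3)nc2c1` is the reference point here. In a functional assay on SV5A8 cells (Homo sapiens) for cytotoxicity (on this read-out lower numbers stand for stronger inhibition and higher numbers for weaker inhibition), compound 2 gives > 8420 nM, which is a limit of the assay rather than a number. Compound 1 `Cc1ccc2c(NCc3ccc(NC(=O)C4CCN(Cc5ccccc5)CC4)cc3)nc(N3CCC(N4CCCC4)CC3)nc2c1` in this assay gives > 8090 nM, likewise a limit. Within the data shown here, the one measured step, a step that the two limits leave unreadable from compound 1 to compound 2, is unreadable because both values sit at the limit of > 8090 nM in this assay, at which 1 of the 2 values shown sits, and (the limit of > 8420 nM in this assay, at which 1 of the 2 values shown sits). Compound 3 `Cc1ccc2c(NCc3ccc(NC(=O)C4CCN(Cc5ccccc5)CC4)cc3)nc(N3CCCC3)nc2c1` differs from compound 2 by pyrrolidin-1-yl in place of 3-(2-hydroxyethyl)piperazin-1-yl on an aromatic carbon. Among the measured compounds shown here, no measured step reads a direction for this change, so compound 3 is expected to stay weak, at an estimated 10000 nM (3000 nM to 30000 nM). The step that the limit leaves unreadable from compound 2 to compound 3 is expected to lie within scatter.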

Compound 3, half-maximal inhibitory concentration: > 7790 nM
Compound 3 was reported as a limit; the forecaster's own chance of this, stated with the estimate: 80%; the middle value lies beyond the limit too.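

In this assay, among these compounds, compound 3 gives > 7790 nM, a limit of the assay, so no step among compound 1, compound 2 and compound 3 can be read. Still open, on these data alone, is how far each compound lies past its limit.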